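Furan pyrimidines: fluoro to methoxy and Vero cytotoxicity

This account rests on a few compounds, and the source may have more. Where it says the series, first, only, none or still open, it means among the compounds named here.

Compounds measured so far:
compound 1, `COc1ccc(COc2cc(-c3ccco3)ncn2)cc1`: "not determined" (no result reported)
compound 2, `COc1ccc(CNc2nc(F)nc(-c3ccco3)c2NC=O)cc1`: > 40 ug/mL

In an ADME assay on Vero cells (Chlorocebus sabaeus) for cytotoxicity, read by MTT assay, with a stated time of 72 h (a higher number here means a weaker inhibitor, a lower number a stronger inhibitor), compound 1 gives "not determined" (no result reported), so it contributes no number. For compound 2 the read-out in this assay is a limit, > 40 ug/mL, and not a measured number. Within the data shown here, this is the one bound available for compound 2 (the limit of > 40 ug/mL in this assay, at which 1 of the 2 values shown sits); no step between two measured compounds exists, so no scale for a change in this assay has been set.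

Compound 3, `COc1ccc(CNc2nc(OC)nc(-c3ccco3)c2NC=O)cc1`, differs from compound 2 in one place: methoxy in place of fluoro on an aromatic carbon. Among the measured compounds shown here, the step is small in size and no measured step shows the effect of such a swap. The expectation is therefore that compound 3 in this assay behaves much as compound 2 does, with a step that the limit leaves unreadable from compound 2 to compound 3 expected to stay within the usual scatter, and most likely again a limit rather than a number. Compound 3 is estimated at 45 ug/mL, in a range from 15 ug/mL to 120 ug/mL.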

Compound 3, half-maximal inhibitory concentration: > 40 ug/mL
Compound 3: only a limit was reported; the forecaster's own chance of this, stated with the estimate: 70%; the middle value is on the limit's open side.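

In this assay, compound 2 and compound 3 are both reported only as limits, so no size can be read for the swap of fluoro to methoxy on the aromatic carbon: the limit of > 40 ug/mL in this assay, at which 2 of the 3 values shown sit.

The compounds shown leave open whether fluoro and methoxy at this place differ at all in this read-out.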